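Notes on an aryl-to-amine swap on the core

This account rests on a few compounds, and the source may have more. Where it says the series, first, only, none or still open, it means among the compounds named here.

Compound 1 `OC[C@H]1C[C@@H](Cn2cnc3c(-c4ccc(Cl)cc4)ncnc32)c2ccccc21` is the reference point for this step. In a functional assay on MOLT-4 cells (Homo sapiens) (on this read-out higher numbers stand for weaker inhibition and lower numbers for stronger inhibition), compound 1 gives 0.63 ug/mL, the lowest of the two numbers recorded so far; the nearest is compound 2, and the gap between the two is beyond the usual scatter. Compound 2 `Cn1ncc2c1[C@H](Cn1cnc3c(Cl)nc(N)nc31)C[C@@H]2CO` in this assay gives 3.2 ug/mL; it is built on a different core and differs from compound 1 in more than one place, so it offers no clean reading on any single change. Compound 3 `CC(C)Nc1ncnc2c1ncn2C[C@@H]1C[C@H](CO)c2ccccc21` keeps the core of compound 1 and differs from it in one group: isopropylamino in place of 4-chlorophenyl on an aromatic carbon. Among the measured compounds shown here, no measured pair isolates that change, and the comparison with compound 2 spans several changes at once and cannot be broken down into parts. The step of a 2.4-fold higher number from compound 1 to compound 3 (0.38 log units; beyond the scatter) is expected to be a modest rise in the number, possibly just beyond the scatter, though the direction is not secure. Compound 3 is estimated to give 1.5 ug/mL in this assay, within a range from 0.4 ug/mL to 6 ug/mL.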

Compound 3, half-maximal inhibitory concentration: 24 ug/mL
Beside the measured number, compound 3's estimate is 16-fold (1.20 log units) below it, and the stated range ends below it.
By their numbers in this assay, from the lowest: compound 1; then compound 2; then compound 3.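

This position on the shared core is far from neutral in this assay: with isopropylamino in place of 4-chlorophenyl on the aromatic carbon, the series shows a 38-fold higher number from compound 1 to compound 3 (1.58 log units; beyond the scatter), its first reading of a change in one place. The group that leaves is a six-membered aromatic ring of carbon only, while the group that enters has no ring, has fewer heavy atoms and brings a hydrogen-bond donor, so this single pair changes several features together and cannot assign the step to any one of them. No available measurement bears on the origin of this large rise.

The compounds shown leave open whether the aromatic ring, the nitrogen link or the size of the group matters most at this carbon; cyclohexyl and anilino groups placed there would help separate those features. Also open, as far as these compounds go, is how far the number depends on the aryl substituent and the amine chain, a question that an unsubstituted phenyl, a 4-methoxyphenyl and a cyclopropylamino group could each address on the core of compound 1.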